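Swapping a Phenylsulfonyl Arm for a Bromophenoxy Acetyl

A few compounds are considered here, and "the series" means these few. Any claim that something is new, unique, unknown or untested is made for them only; others in the source may bear on it.

Compound 1 `Nc1nc(N2CCN(S(=O)(=O)c3ccccc3)CC2)c2nc(-c3ccc(F)cc3)sc2n1` was tested in a functional assay on cells (Lymphocyte, Homo sapiens) (a higher number here means a weaker inhibitor, a lower number a stronger inhibitor), and compound 1 gave only a limit of the assay, > 10000 nM, not a number. That is the limit of > 10000 nM in this assay, at which 1 of the 3 values shown sits, so compound 1 sits at the weak edge of what is shown, with no exact position known. Two related compounds carry a chlorophenoxy acetyl group on the same amine nitrogen in a ring but a chain instead of a direct aryl on the other side of the core: compound 2 `Nc1nc(N2CCN(C(=O)COc3ccc(Cl)cc3)CC2)c2nc(CCc3ccc(F)cc3)sc2n1` gives 4400 nM in this assay, and compound 3 `Nc1nc(N2CCN(C(=O)COc3ccc(Cl)cc3)CC2)c2nc(CCOc3ccc(F)cc3)sc2n1` gives 3540 nM. Among the measured compounds shown here, the one measured step, a 1.2-fold lower number from compound 2 to compound 3 (0.09 log units; within the scatter), concerns the chain end and not the amide arm, so it does not bear directly on the change studied here.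

Compound 4 `Nc1nc(N2CCN(C(=O)COc3ccc(Br)cc3)CC2)c2nc(-c3ccc(F)cc3)sc2n1` differs from compound 1 in one place: ((4-bromophenoxy)methyl)carbonyl in place of phenylsulfonyl on an amine nitrogen in a ring. For the measured compounds named here, no measured step covers this exact exchange; compounds 2 and 3 show only that the related chlorophenoxy acetyl arm, paired with a chain, gives measurable inhibition. Compound 4 keeps the direct aryl of compound 1, so the expectation is modest. Compound 4 is expected to reach 5000 nM, within 1500 nM to 20000 nM. That expected step is an at least 2.0-fold lower number from compound 1 to compound 4 (0.30 log units; that floor lies within the scatter), with a real chance that compound 4 again returns only a limit.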

Compound 4, half-maximal inhibitory concentration: 380 nM
Estimate against measurement, compound 4: 13-fold (1.12 log units) above; the whole stated range lies above it.
By their numbers in this assay, from the lowest: compound 4; then compounds 3 and 2 (each within the scatter of the next). At a limit, above all of these: compound 1.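

The exchange of phenylsulfonyl for ((4-bromophenoxy)methyl)carbonyl on an amine nitrogen in a ring brings, in this assay, an at least 26-fold lower number from compound 1 to compound 4 (1.42 log units; beyond the scatter). This shows that the group at this position has a large bearing on the result: with the rest of compound 1 left as it is, changing this arm alone yields compound 4, which has a measured number rather than a limit. It also shows that measurable inhibition does not depend on the chain carried by compound 2 and compound 3, since compound 4 keeps the direct aryl of compound 1, though the exact size of the step remains unknown because compound 1 stands at a limit of the assay: the limit of > 10000 nM in this assay, at which 1 of the 4 values shown sits.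

The change replaces the sulfonyl with a carbonyl, lengthens the arm and adds a bromine all at once, so the compounds shown cannot say which of these parts accounts for the step. A phenoxyacetyl arm with no halogen, a plain benzoyl group or a phenylsulfonyl group carrying a bromine would each separate these parts, and the same arm with a chlorine on the direct-aryl compound would test the halogen alone.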